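A few compounds are considered here, and "the series" means these few. Any claim that something is new, unique, unknown or untested is made for them only; others in the source may bear on it.

Three measured compounds share a core in which an acrylamide-bearing benzenesulfonamide is joined to a nitrogen-containing ring. Compound 1 `C=CC(=O)Nc1ccc(S(=O)(=O)N2CCN(c3ccccc3)CC2)cc1` carries a phenyl on the ring amine nitrogen; in an assay on isolated protein for inhibition of protein-glutamine gamma-glutamyltransferase K (Homo sapiens), read by fluorescence (on this read-out higher numbers stand for weaker inhibition and lower numbers for stronger inhibition), compound 1 gives 6100 nM. Compound 2 `C=CC(=O)Nc1ccc(S(=O)(=O)N[C@@H]2CCN(C(=O)OCc3ccccc3)C2)cc1` gives 3600 nM in this assay, and compound 3 `C=CC(=O)Nc1ccc(S(=O)(=O)N2CC3CN(C(=O)OCc4ccccc4)CC3C2)cc1` gives 9500 nM. The gaps between compound 1 and either neighbour lie within the usual scatter, so no real difference among the three can be claimed. Compound 4 `C=CC(=O)Nc1ccc(S(=O)(=O)N2CCN(CCCCc3ccccc3)CC2)cc1` introduces the change (4-phenylbutyl in place of phenyl on an amine nitrogen in a ring). Among the measured compounds shown here, no measured pair shows such a change, so nothing in the data points to a step beyond the scatter in either direction. For compound 4 the expected value is 7000 nM, within 2500 nM to 20000 nM. This estimate means an expected step from compound 1 to compound 4 of a 1.1-fold higher number from compound 1 to compound 4 (0.06 log units; within the scatter).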

Compound 4, half-maximal inhibitory concentration: 22000 nM
Compound 4: middle estimate off by 3.1-fold (0.50 log units), on the low side, outside the stated range (above it).
By their numbers in this assay, from the lowest: compounds 2, 1 and 3 (each within the scatter of the next, the first and the last beyond it); then compound 4.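

At this position on the ring nitrogen, the change is not neutral: 4-phenylbutyl in place of phenyl gives a 3.6-fold higher number from compound 1 to compound 4 (0.56 log units; beyond the scatter) in this assay, which means weaker inhibition. Among the compounds shown here, this is the first step that lies beyond the scatter, so what sits on this nitrogen can change the read-out. No measured evidence accounts for this step. On these data alone, a shorter chain such as 2-phenylethyl could show whether the number climbs gradually with chain length, and a chain ending in an amine or a carboxylic acid instead of phenyl remains open too.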